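The source may report more compounds than this note shows. Statements on the series, on what has been measured and on what is new or still open speak of the compounds shown alone.

Measured compounds

compound 1 `O=C(O)c1ccc(NCc2cccc(Oc3ccccc3)c2)cc1` — in a functional assay on CHO cells for agonist activity at Free fatty acid receptor 1 (Homo sapiens) (on this read-out lower numbers stand for an effect already at smaller amounts and higher numbers for an effect only at larger amounts of compound), compound 1 gives < 10000 nM, which is a limit of the assay and not a number.
compound 2 `Cc1nc(-c2ccc(C(F)(F)F)cc2)sc1CNc1ccc(OCC(=O)O)cc1` — in this assay compound 2 gives 288 nM.

Compound 2 therefore stands on the only number shown in this assay; the other entry is a limit, as stated in the limit of < 10000 nM in this assay, at which 1 of the 2 values shown sits. Among the measured compounds shown here, no step between measured compounds is available, since compound 1 and compound 2 differ in more than one place, so nothing about the size of a single structural change has been measured here.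

Compound 3 `Cc1nc(-c2ccc(C(F)(F)F)cc2)sc1CNc1ccc([C@H]2C[C@@H]2C(=O)NO)cc1` is not yet measured. It differs from compound 2 in one place: 2-(hydroxycarbamoyl)cyclopropyl in place of carboxymethoxy on an aromatic carbon. The change is the replacement of the carboxymethoxy group by a 2-(hydroxycarbamoyl)cyclopropyl group, with the shared core of compound 2 otherwise unchanged.

For the measured compounds named here, with no measured step to lean on, the expectation for the step from compound 2 to compound 3 is a move toward larger amounts, beyond the scatter: a 5.2-fold higher number from compound 2 to compound 3 (0.72 log units; beyond the scatter). Going by these compounds, compound 3 is accordingly estimated at 1500 nM in this assay, with a range from 300 nM to 8000 nM, and the outcome remains open until the measurement is in hand.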

Compound 3, half-maximal effective concentration: 6.92 nM
For compound 3 the middle estimate is 220-fold (2.34 log units) above the measured one, and the stated range ends above it.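

Working notes on the series: at this position, on an aromatic carbon para to a large group, agonist activity in this assay does not depend on the carboxymethoxy group, since 2-(hydroxycarbamoyl)cyclopropyl in its place gives a 42-fold lower number from compound 2 to compound 3 (1.62 log units; beyond the scatter). Among the compounds shown here, this is the first measured single-place change, and it shows that the position accepts a larger group containing a three-membered carbon ring and two defined stereocentres, with a large move toward a lower number rather than a loss of effect. No measurement shown gives a cause for this step.

The compounds shown do not separate the contribution of the cyclopropyl ring from that of the hydroxycarbamoyl end, a question that a carboxylic acid on the same cyclopropyl ring or a hydroxycarbamoyl group on a plain carbon chain would address. For the compounds shown here, also open is what the two defined stereocentres contribute, as only one arrangement of the ring substituents appears here, and whether the step carries over to other changes on the shared core.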